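The source may hold more compounds than are shown below. What is called first, only, known or untested is meant among the compounds shown, and "the series" means these compounds.

Working notes on the series. The shared core carries a dimethoxyphenyl sulfide on one side and a variable group on the other. Compound 1 `COc1ccc(OC)c(Sc2ccc3nnc(-c4ccccc4)n3n2)c1` gives 1380 nM in an assay on HEK293 cells for inhibition of Leucine-rich repeat serine/threonine-protein kinase 2 (Homo sapiens), read by ELISA, with a stated time of 90 min; a higher number here means a weaker inhibitor, a lower number a stronger inhibitor. Compound 2 `COc1cncc(-c2nnc3ccc(Sc4cc(OC)ccc4OC)nn23)c1` gives 440 nM in this assay, and the step of a 3.1-fold lower number from compound 1 to compound 2 (0.50 log units; beyond the scatter) follows the exchange of phenyl for 5-methoxypyridin-3-yl at that position. Compound 3 `COc1ccc(OC)c(Sc2ccc3nnc(Cc4cnn(C)c4)n3n2)c1` carries (1-methyl-1H-pyrazol-4-yl)methyl there, but in this assay compound 3 gives "not determined" (no result reported), so compound 3 stands without a number.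

Compound 4 `COc1ccc(OC)c(Sc2ccc3nnc(-c4ccsn4)n3n2)c1` differs from compound 3 by 1,2-thiazol-3-yl in place of (1-methyl-1H-pyrazol-4-yl)methyl on an aromatic carbon. Among the compounds with values here, no measured step mirrors this change; the only step available, from compound 1 to compound 2, concerns a six-membered aromatic group at the same position and shows that a variation of the aromatic group there can move the number modestly. Since compound 4 keeps a directly attached aromatic ring, like compound 1 and compound 2, its value is expected to fall in the region those two define. Compound 4 is therefore estimated at 800 nM in this assay, with an expected range from 250 nM to 3000 nM around it.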

Compound 4, half-maximal inhibitory concentration: 722 nM
The estimate for compound 4 lay 1.1-fold (0.04 log units) above the measured number; measured number inside the range.
By their numbers in this assay, from the lowest: compounds 2, 4 and 1 (each within the scatter of the next, the first and the last beyond it).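

At this position, a directly attached five-membered aromatic ring, 1,2-thiazol-3-yl, gives a number in this assay that cannot be separated from either six-membered group: the record shows a 1.6-fold higher number from compound 2 to compound 4 (0.22 log units; within the scatter) and a 1.9-fold lower number from compound 1 to compound 4 (0.28 log units; within the scatter). Compound 4 thus stands within the scatter of both compound 1 and compound 2, although those two lie beyond the scatter of each other. The step from compound 3 to compound 4 cannot be read, and no supporting measurement bears on this result.

As far as these compounds go, the dimethoxyphenyl sulfide stays the same in all four compounds, so the effect of changing it remains open. Also open, from the compounds shown here alone, is how an amine such as morpholine or a carboxylic acid would read at this position, and whether a methylene-linked group such as that of compound 3 would give a number at all.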